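The source may report more compounds than this note shows. Statements on the series, on what has been measured and on what is new or still open speak of the compounds shown alone.

Measured compounds:
- compound 1, `CC1=C(C(=O)OCc2ccccc2)C(c2ccco2)NC(=O)N1`: 3%
- compound 2, `CCCOC(=O)C1=C(C)NC(=O)NC1c1ccoc1`: 11%

Of the compounds shown here, two have been tested so far in an assay on membranes from HeLa cells for displacement of a labelled ligand from adenosine receptor A3 (Homo sapiens), read by scintillation counting, with a stated time of 180 min, tested at 1 uM; on this read-out higher numbers stand for more inhibition at the one concentration tested (going by the name of the read-out) and lower numbers for less inhibition. Compound 1 gives 3% in this assay, and compound 2 gives 11%. Compound 2 holds the higher of the two numbers, but the gap to compound 1 lies within the usual scatter, so the two readings cannot be told apart; both stand low on this scale.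

The step now followed leads from compound 2 to compound 3, `CC1=C(C(=O)OCc2ccccc2)C(c2ccoc2)NC(=O)N1`. The change is phenyl in place of ethyl on a saturated chain carbon bound to an oxygen next to a carbonyl group. Compound 1 and compound 2 differ in more than one place, so their two values give no direct guide to this single change; all that is seen is that both measured compounds sit at the low end.

For the measured compounds named here, with no measured step of this kind to lean on, no move beyond the scatter is expected in this assay in either direction. Compound 3 is expected to give 8%, within 0% to 25%, an estimated step of a number 3 percentage points lower from compound 2 to compound 3 (within the scatter).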

Compound 3, a percentage reported as inhibition, at one concentration (the size of the read-out at that concentration, not a potency): 1%
Estimate against measurement, compound 3: 7 percentage points above; measured number inside the range.
By their numbers in this assay, from the lowest: compounds 3, 1 and 2 (each within the scatter of the next).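

In this assay, for the compounds shown here, this place can now be read directly for the first time, through phenyl in place of ethyl on a saturated chain carbon bound to an oxygen next to a carbonyl group: a number 10 percentage points lower from compound 2 to compound 3 (within the scatter) shows that exchanging this short chain end for a six-membered aromatic ring, which also reads as propyl to benzyl, gives no change that can be told from repeat-measurement noise. Compound 3 also gives a second single-change comparison, furan-3-yl in place of furan-2-yl on a saturated ring carbon, and a number 2 percentage points lower from compound 1 to compound 3 (within the scatter) shows that this swap likewise cannot be told apart from no change at all. No measurement at hand explains either reading.

All three compounds stay at the low end of the scale, so these comparisons show no group that raises the reading and cannot separate small effects from none. Still open, as far as these compounds go, is whether a longer chain, an amine or a carboxylic acid at the chain position, or a pyridine ring in place of the furan, would lift inhibition clearly above this low level.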